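A Propyl-to-Isopropyl Swap at the Sulfur

The source may report more compounds than this note shows. Statements on the series, on what has been measured and on what is new or still open speak of the compounds shown alone.

Compound 1 `CCCCCCCCSC1=CC(=O)C(C[C@]2(C)[C@@H](C)CC[C@]3(C)C(C)=CCC[C@@H]23)=CC1=O`: > 100000 nM in a functional assay on HeLa cells (Homo sapiens) for cytotoxicity (a lower number here means a stronger inhibitor, a higher number a weaker inhibitor), a limit of the assay.
Compound 2 `CCCSC1=CC(=O)C(C[C@]2(C)[C@@H](C)CC[C@]3(C)C(C)=CCC[C@@H]23)=CC1=O`: 97000 nM in this assay.

Going by the values given here, compound 2 holds the only number in this assay; the other value shown is a limit. Among the compounds with values here, the only measured step, an at least 1.0-fold lower number from compound 1 to compound 2 (0.01 log units; that floor lies within the scatter), exchanges pentyl for hydrogen on a saturated chain carbon, three bonds along the chain from a sulfur, and cannot be sized because one value sits at the limit (the limit of > 100000 nM in this assay, at which 1 of the 2 values shown sits). Compound 3 `CC1=CCC[C@H]2[C@](C)(CC3=CC(=O)C(SC(C)C)=CC3=O)[C@@H](C)CC[C@]12C` differs from compound 2 by isopropyl in place of propyl on a sulfur. Within the data shown here, no measured step touches the group on the sulfur, so the step is expected to stay within the scatter, a 1.0-fold higher number from compound 2 to compound 3 (0.01 log units; within the scatter). Compound 3 is estimated at 100000 nM, between 40000 nM and 250000 nM.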

Compound 3, half-maximal inhibitory concentration: 67000 nM
The estimate for compound 3 lay 1.5-fold (0.17 log units) above the measured number; the range from low to high includes it.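

Isopropyl in place of propyl on a sulfur gives the first step at this group that can be read: a 1.4-fold lower number from compound 2 to compound 3 (0.16 log units; within the scatter). Compound 2 and compound 3 therefore cannot be told apart in this assay, whether the three-carbon chain is straight or branched. Compound 1 stands at a limit. Isopropyl in place of octyl on a sulfur gives an at least 1.4-fold lower number from compound 1 to compound 3 (0.17 log units; that floor lies within the scatter), and that floor is all this step shows: the limit of > 100000 nM in this assay, at which 1 of the 3 values shown sits.

The compounds shown leave open whether a group on the sulfur that is not a simple alkyl chain, such as a carboxylic acid or an amine, would carry the number beyond the scatter.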